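The compounds below may be only part of what the source reports. "The series", "measured", "known", "first", "only" and "open" are said of these compounds alone.

For the measured compounds named here, compound 2 `Oc1ccc(/C=N/NC(=S)Nc2cccc(Cl)c2)cc1` gives 29300 nM in an assay for inhibition of ribonucleoside-diphosphate reductase RR1 (Homo sapiens), with a stated time of 30 min (on this read-out lower numbers stand for stronger inhibition and higher numbers for weaker inhibition), the lowest of the three numbers so far. Compound 3 `Cc1ccccc1NC(=S)N/N=C/c1ccc(O)cc1` gives 36500 nM in this assay, a number that lies within the scatter of compound 2. Compound 1 `Oc1ccc(/C=N/NC(=S)Nc2ccccc2)cc1` gives 242000 nM in this assay, well beyond compound 2.

Compound 4 `Cc1cccc(NC(=S)N/N=C/c2ccc(O)cc2)c1` differs from compound 2 by one change, (methyl in place of chloro on an aromatic carbon). Going by the values given here, two measured steps bear on it. Adding chloro gave an 8.3-fold lower number from compound 1 to compound 2 (0.92 log units; beyond the scatter), while adding methyl, though on another aromatic carbon, gave a 6.6-fold lower number from compound 1 to compound 3 (0.82 log units; beyond the scatter). Chloro and methyl thus gave gains of similar size from the same starting point, and the gap between those two steps is small. Swapping one for the other at the place where chloro sits in compound 2 is therefore expected to move the number little, if at all, beyond the scatter in this assay.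

For compound 4 the expected step is a 1.2-fold higher number from compound 2 to compound 4 (0.08 log units; within the scatter), so compound 4 is estimated to give 35000 nM in this assay, within a range from 15000 nM to 80000 nM.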

Compound 4, half-maximal inhibitory concentration: 30400 nM
The estimate for compound 4 lay 1.2-fold (0.06 log units) above the measured number; low and high end bracket the measured number.
By their numbers in this assay, from the lowest: compounds 2, 4 and 3 (each within the scatter of the next); then compound 1.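

At this place on the aromatic ring, meta to a large group, methyl and chloro cannot be told apart in this assay: the swap gives a 1.0-fold higher number from compound 2 to compound 4 (0.02 log units; within the scatter). Methyl at this same place also brings a clear gain of its own, with an 8.0-fold lower number from compound 1 to compound 4 (0.90 log units; beyond the scatter), so among the compounds shown the gain here does not depend on chlorine being the added atom. No measurement shown explains why the two groups match.

On these data alone, both groups compared here hold a single heavy atom, so whether a longer chain, an amine or a carboxylic acid at this place would keep the gain stays open. Whether chloro and methyl also match on the other aromatic carbons of this ring is open too, as the direct comparison covers only this one place.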